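The source may hold more compounds than are shown below. What is called first, only, known or untested is meant among the compounds shown, and "the series" means these compounds.

Measured compounds in a functional assay on HepG2 cells (Homo sapiens) for cytotoxicity, with a stated time of 24 h; on this read-out lower numbers stand for stronger inhibition and higher numbers for weaker inhibition:
compound 1 `O=C(N/N=C/c1cc(I)cc(I)c1O)c1ccc(F)cc1`: 12100 nM
compound 2 `O=C(N/N=C/c1cc(I)cc(I)c1O)c1ccc(Cl)cc1`: 14800 nM
compound 3 `O=C(N/N=C/c1cc(I)c(O)c(I)c1)c1ccc(F)cc1`: 117000 nM

Compound 1 and compound 2 share one core and differ by chloro in place of fluoro on an aromatic carbon, a change that produced a 1.2-fold higher number from compound 1 to compound 2 (0.09 log units; within the scatter). Compound 3 is built from the same atoms as compound 1 joined differently; the difference between the two cores is not broken down here. Compound 3 stands apart with the highest number of the three, beyond the scatter from both others.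

Compound 4 `O=C(N/N=C/c1cc(I)c(O)c(I)c1)c1ccc(Cl)cc1` carries the same change on the core of compound 3: chloro in place of fluoro on an aromatic carbon. Since the place of the change is described in the same words for both pairs, a step of similar size is expected, that is a 1.2-fold higher number from compound 3 to compound 4 (0.06 log units; within the scatter), resting on the small step of a 1.2-fold higher number from compound 1 to compound 2 (0.09 log units; within the scatter). Compound 4 is therefore estimated at 135000 nM, likely between 60000 nM and 300000 nM.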

Compound 4, half-maximal inhibitory concentration: > 100000 nM
Compound 4 was reported as a limit (the forecaster's own chance of this, stated with the estimate: 20%); the middle value lies beyond the limit too.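

Compound 4 is reported only as a limit, so the step from compound 3 to compound 4 cannot be read: the limit of > 100000 nM in this assay, at which 1 of the 4 values shown sits.

Open stays whether chloro in place of fluoro moves the number as little on the core of compound 3 as on the core of compound 1.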